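The source may hold more compounds than are shown below. What is called first, only, known or untested is meant among the compounds shown, and "the series" means these compounds.

Working notes on a set of four closely related compounds. Compound 1 `ClCc1ccccc1Cn1cnc2c(Cl)nc(Cl)nc21`, compound 2 `ClCc1ccccc1Cn1cnc2c(Cl)ncnc21` and compound 3 `ClCc1ccccc1Cn1cnc2ncnc(Cl)c21` have been measured in a functional assay on Hs-578T cells (Homo sapiens) for cytotoxicity, read by sulforhodamine B assay, with a stated time of 48 h; on this read-out lower numbers stand for higher toxicity in this test and higher numbers for lower toxicity in this test; compound 4 `ClCc1ccccc1Cn1cnc2nc(Cl)nc(Cl)c21` has not.

In this assay compound 1 reaches only a limit, > 100000 nM, which is not a number. In this assay compound 2 gives 56200 nM. In this assay compound 3 gives 66100 nM. Compound 3 and compound 2 lie within the usual scatter of each other, so no order between them is read.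

Compound 1 differs from compound 2 by chloro in place of hydrogen on an aromatic carbon. The step of an at least 1.7-fold higher number from compound 2 to compound 1 (0.25 log units; that floor lies within the scatter) is known only as a floor because compound 1 sits at the limit of > 100000 nM in this assay, at which 1 of the 3 values shown sits.

Compound 4 differs from compound 3 by chloro in place of hydrogen on an aromatic carbon. For the measured compounds named here, this is the same change as the one from compound 2 to compound 1; the two cores of compound 2 and compound 3 hold the same atoms joined differently, and that difference is not broken down here.

For compound 4 the expected step is a 1.7-fold higher number from compound 3 to compound 4 (0.22 log units; within the scatter). This expectation rests on the measured step of an at least 1.7-fold higher number from compound 2 to compound 1 (0.25 log units; that floor lies within the scatter), whose floor leaves the true size open. It also starts from the measured value of compound 3, 66100 nM. Compound 4 is therefore estimated at 110000 nM, with an expected range from 55000 nM to 250000 nM, and with a fair chance that this assay reports only a limit.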

Compound 4, concentration lethal to 50% of the cells: > 100000 nM
Compound 4: no number, only a limit (the forecaster's own chance of this, stated with the estimate: 55%); the middle value lies beyond the limit too.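

In this assay compound 4 reaches only a limit, > 100000 nM, which is not a number. Chloro in place of hydrogen on an aromatic carbon therefore gives an at least 1.5-fold higher number from compound 3 to compound 4 (0.17 log units; that floor lies within the scatter), so on each of the two cores this step is known only as a floor: the same change on two cores in this assay, an at least 1.7-fold higher number (0.25 log units; that floor lies within the scatter) from compound 2 to compound 1 and an at least 1.5-fold higher number (0.17 log units; that floor lies within the scatter) from compound 3 to compound 4; the limit leaves it open whether they differ. Nothing here contradicts carrying the change from one core to the other, but the true size of the step on either core cannot be read, and with both floors within the scatter, even a real shift is not established; the comparison is capped by: the limit of > 100000 nM in this assay, at which 2 of the 4 values shown sit.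

The compounds shown hold only chloro or hydrogen on the aromatic carbon between two ring nitrogen atoms, which leaves open whether an amine, a methoxy group or a longer chain at that place would give a measured number rather than a limit on either core. Also open, on these data alone, is whether any change that yields numbers on both cores would show the same step on each, a question that only values clear of the limit in this assay could answer.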